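Working notes: substituent change from compound 2 to compound 3

The source may hold more compounds than are shown below. What is called first, only, known or untested is meant among the compounds shown, and "the series" means these compounds.

Measured so far in an assay for inhibition of Amine oxidase [flavin-containing] A (Homo sapiens); a lower number here means a stronger inhibitor, a higher number a weaker inhibitor:
compound 1 `O=C1O[C@@H](Cn2ccnn2)CN1c1ccc(-c2ccc(CO)nc2)c(F)c1` gives 4800 nM
compound 2 `COCc1ccc(-c2ccc(N3C[C@H](Cn4ccnn4)OC3=O)cc2F)cn1` gives 1700 nM

Compound 2 holds the lowest of the two numbers in this assay; its nearest neighbour is compound 1, and the step of a 2.8-fold lower number from compound 1 to compound 2 (0.45 log units; beyond the scatter) is modest but beyond the scatter. Compound 3 `O=C(c1ccc(-c2ccc(N3C[C@H](Cn4ccnn4)OC3=O)cc2F)cn1)C1CCNCC1` carries (piperidin-4-yl)carbonyl in place of methoxymethyl on an aromatic carbon. Among the compounds with values here, the only measured step, a 2.8-fold lower number from compound 1 to compound 2 (0.45 log units; beyond the scatter), concerns a far smaller change at the same part of the structure, so it gives little guidance for a change of this size and kind. Within the data shown here, no measured pair shows what a larger group here does. The expectation for compound 3 in this assay is therefore set close to compound 2, with a wide range in both directions, amounting to a 1.1-fold lower number from compound 2 to compound 3 (0.05 log units; within the scatter). Compound 3 is estimated at 1500 nM, within 300 nM to 8000 nM.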

Compound 3, inhibition constant: > 44000 nM
Compound 3 gave a limit, no number (the forecaster's own chance of this, stated with the estimate: 5%); middle value at least 29-fold (1.46 log units) away from the limit.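

Compound 3 gives a limit in this assay, not a number: the limit of > 44000 nM in this assay, at which 1 of the 3 values shown sits.

On this aromatic carbon, next to the ring nitrogen, (piperidin-4-yl)carbonyl in place of methoxymethyl gives an at least 25-fold higher number from compound 2 to compound 3 (1.41 log units; beyond the scatter), and in place of hydroxymethyl it gives an at least 9.1-fold higher number from compound 1 to compound 3 (0.96 log units; beyond the scatter). The earlier pair showed only a modest step at this position, whereas these steps show that the substituent here can shift the reading in this assay much further, and in the direction of weaker inhibition.

The change brings in the carbonyl, the saturated ring and the ring nitrogen together, so the compounds shown do not separate their contributions. A cyclohexylcarbonyl group, which lacks the ring nitrogen, or a simple acetyl group, which lacks the ring, would help to tell which part goes with the loss.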